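From pyrimidin-2-yl to pyridazin-3-yl

The source may report more compounds than this note shows. Statements on the series, on what has been measured and on what is new or still open speak of the compounds shown alone.

In a physicochemical assay for lipophilicity, read by HPLC, measured as chromatographic lipophilicity, at pH 7.4 (a higher number here means a more lipophilic compound, a lower number a more polar compound), compound 1 (`Cc1ccc(C2CC=NN2C(=O)C(C)(C)C)cc1`) gives 6.4 and compound 2 (`O=C(C1CCN(c2ncccn2)CC1)N1N=CC[C@H]1c1ccccc1`) gives 4.7 on the same scale. Compound 2 holds the lower of these two numbers, and its gap to compound 1 lies beyond the usual scatter. Compound 3 (`O=C(C1CCN(c2cccnn2)CC1)N1N=CC[C@H]1c1ccccc1`) carries pyridazin-3-yl in place of pyrimidin-2-yl on an amine nitrogen in a ring with the same atoms joined differently. Going by the values given here, no measured step covers this change, so what follows is a judgement from the structures alone. A fall beyond the scatter is expected in this assay with an estimated step of a number 0.80 log units lower from compound 2 to compound 3 (beyond the scatter) overall. Compound 3 is expected at 3.9 with a range of 3.3 to 4.5 for this estimate.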

Compound 3, distribution coefficient: 3.4
For compound 3 the middle estimate is 0.50 log units above the measured one; low and high end bracket the measured number.
By their numbers in this assay, from the lowest: compound 3; then compound 2; then compound 1.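

Swapping pyrimidin-2-yl for pyridazin-3-yl on the amine nitrogen in a ring uses the same atoms, joined differently, yet gives a number 1.30 log units lower from compound 2 to compound 3 (beyond the scatter) in this assay and counts as a large step. At this position, then, the arrangement of atoms within the aromatic ring matters on its own, even though the counts of heavy atoms, hydrogen-bond donors and hydrogen-bond acceptors stay the same. Nothing available explains the size of this step. Where pyridin-2-yl or pyrazin-2-yl would fall on this scale remains open, as does whether the same swap gives a similar step in a different molecule.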